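The source may report more compounds than this note shows. Statements on the series, on what has been measured and on what is new or still open speak of the compounds shown alone.

Measured compounds in the series:

Compound 1 `ClCCOC[C@H]1CO1`: in an ADME assay on BHK cells (Mesocricetus auratus) for cytotoxicity, read by XTT assay (on this read-out lower numbers stand for higher toxicity in this test and higher numbers for lower toxicity in this test), compound 1 gives > 1000000 nM, a limit of the assay rather than a number.
Compound 2 `ON=C(C[C@@H]1COCCO1)C[C@@H]1COCCO1`: in this assay compound 2 gives > 1000000 nM, again a limit of the assay.
Compound 3 `C1CSC(CC[C@@H]2COCCO2)(C[C@@H]2COCCO2)SC1`: in this assay compound 3 gives > 1000000 nM, once more a limit of the assay.

Compound 3 thus stands where every measured compound stands: at the limit of > 1000000 nM in this assay, at which 3 of the 3 values shown sit. Within the data shown here, no numbered value exists for any of the three, so no measured step between them can be sized, and nothing separates compound 3 from compound 1 or compound 2 on these readings.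

The unmeasured compound 4 `C1CSC(C[C@H]2COCCO2)(C[C@@H]2COCCO2)SC1` differs from compound 3 by 1,4-dioxan-2-yl in place of (1,4-dioxan-2-yl)methyl on a saturated chain carbon bound to a saturated ring carbon. Among the measured compounds shown here, with no step measured and all values sitting at the same limit, no step beyond the scatter is expected in this assay, in either direction. Compound 4 is therefore expected to give 1000000 nM, with a range from 500000 nM to 2000000 nM, most likely reported again as a limit. The expected step is a number no higher from compound 3 to compound 4 (the limit leaves the size open), that is, none beyond the scatter.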

Compound 4, half-maximal cytotoxic concentration: > 1000000 nM
Compound 4 was reported as a limit (the forecaster's own chance of this, stated with the estimate: 85%); the middle value lies on the limit itself.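

Compound 3 and compound 4 both sit at a limit of the assay in this assay, so no step between them can be read: the limit of > 1000000 nM in this assay, at which 4 of the 4 values shown sit.

The compounds shown leave open where any of them would fall as a number in this assay, and whether 1,4-dioxan-2-yl in place of (1,4-dioxan-2-yl)methyl makes any difference.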